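The source may hold more compounds than are shown below. What is called first, only, known or untested is meant among the compounds shown, and "the series" means these compounds.

Two compounds anchor this series. Compound 1 `Cc1nc(C(F)(F)F)ccc1C(=O)Nc1ccc(Cl)c(-c2cn3ccsc3n2)c1` gives 200 nM in an assay on C3H 10T1/2 cells for inhibition of Sonic hedgehog protein (Mus musculus), read by a luciferase reporter (a higher number here means a weaker inhibitor, a lower number a stronger inhibitor), and compound 2 `Cc1nc(C(F)(F)F)ccc1C(=O)Nc1ccc(Cl)c(-n2cccn2)c1` gives 450 nM in the same test. Within the data shown here, compound 2 therefore stands as the higher of the two numbers, the weaker inhibitor, and the only step measured so far is a 2.3-fold higher number from compound 1 to compound 2 (0.35 log units; beyond the scatter), a modest shift. Compound 3 `Cc1nc(C(F)(F)F)ccc1C(=O)Nc1ccc(Cl)c(-c2ccn(C)n2)c1` differs from compound 2 in one place: 1-methyl-1H-pyrazol-3-yl in place of 1H-pyrazol-1-yl on an aromatic carbon. This change keeps a five-membered aromatic ring with two hetero atoms in the same place, so it is smaller than the step from compound 1 to compound 2, which swapped a two-ring group for a one-ring group. Among the measured compounds shown here, no measured pair mirrors a carbon-linked, methyl-bearing ring in place of a nitrogen-linked one, so the direction is uncertain, and compound 3 is expected to sit near compound 2, with any step a 1.3-fold lower number from compound 2 to compound 3 (0.11 log units; within the scatter) likely within the scatter. The estimate for compound 3 is 350 nM, spanning 130 nM to 900 nM.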

Compound 3, half-maximal inhibitory concentration: 550 nM
The estimate for compound 3 lay 1.6-fold (0.20 log units) below the measured number; measured number inside the range.
By their numbers in this assay, from the lowest: compound 1; then compounds 2 and 3 (each within the scatter of the next).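

Replacing 1H-pyrazol-1-yl with 1-methyl-1H-pyrazol-3-yl on this aromatic carbon, ortho to a chloro group, gives a 1.2-fold higher number from compound 2 to compound 3 (0.09 log units; within the scatter) in this assay, so at this position the two single-ring groups cannot be told apart. Both also lie on the same side of the two-ring group of compound 1, with a 2.8-fold higher number from compound 1 to compound 3 (0.44 log units; beyond the scatter) adding to a 2.3-fold higher number from compound 1 to compound 2 (0.35 log units; beyond the scatter), and neither single-ring compound goes against this. No measurement here offers an explanation for these numbers.

The step changes both the ring's linking atom and the methyl group at once, leaving their separate contributions open, and a 1H-pyrazol-3-yl ring without the methyl would be needed to pull them apart. Also open, going by these compounds, is how this position responds to a quite different group, such as an amine or a carboxylic acid.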